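The compounds below may be only part of what the source reports. "The series", "measured", "known", "first", "only" and "open" are said of these compounds alone.

Compound 3 `COc1cc2c(Oc3ccc(NC(=O)c4nn(-c5ccccc5C(F)(F)F)c(=O)cc4C)cc3F)ccnc2cc1OCCCN1CCCCC1` gives 1150 nM in a functional assay on U-87MG ATCC cells (Homo sapiens) for inhibition, read by MTT assay, with a stated time of 72 h (on this read-out lower numbers stand for stronger inhibition and higher numbers for weaker inhibition), the second highest of the three numbers in hand. Compound 2 `COc1cc2c(Oc3ccc(NC(=O)c4nn(-c5ccccc5C(F)(F)F)c(=O)cc4C)cc3F)ccnc2cc1OCCCN1CCCC1` gives 1010 nM, and compound 1 `COc1cc2c(Oc3ccc(NC(=O)c4nn(-c5ccccc5C)c(=O)cc4C)cc3F)ccnc2cc1OCCCN1CCC(C)CC1` gives 2240 nM; both gaps to compound 3 lie within the scatter. Compound 4 `COc1cc2c(Oc3ccc(NC(=O)c4nn(-c5ccccc5C(F)(F)F)c(=O)cc4C)cc3F)ccnc2cc1OCCCN1CCC(C)CC1` differs from compound 3 by methyl in place of hydrogen on a saturated ring carbon. Going by the values given here, the only single-change step measured, a 1.1-fold higher number from compound 2 to compound 3 (0.06 log units; within the scatter), concerned the ring itself rather than a methyl on it. Among the compounds with values here, compound 1 carries the same 4-methylpiperidin-1-yl as compound 4 but is not a single-change neighbour of compound 3, so its value shows only that a methylated ring can go with a number within the scatter of compound 3. No step beyond the scatter is therefore expected from compound 3 to compound 4 in this assay, a 1.1-fold higher number from compound 3 to compound 4 (0.05 log units; within the scatter). Compound 4 is expected at 1300 nM, within 600 nM to 2800 nM.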

Compound 4, half-maximal inhibitory concentration: 1120 nM
Estimate against measurement, compound 4: 1.2-fold (0.06 log units) above; the measured number falls inside the stated range.
By their numbers in this assay, from the lowest: compounds 2, 4, 3 and 1 (each within the scatter of the next, the first and the last beyond it).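

In this assay the methyl on this saturated ring carbon, three ring bonds from the ring nitrogen, gives a 1.0-fold lower number from compound 3 to compound 4 (0.01 log units; within the scatter) and so adds nothing measurable to the piperidin-1-yl compound. The wider ring swap gives a 1.1-fold higher number from compound 2 to compound 4 (0.04 log units; within the scatter) and trifluoromethyl in place of methyl on an aromatic carbon gives a 2.0-fold lower number from compound 1 to compound 4 (0.30 log units; within the scatter) so neither change separates these compounds either. No supporting evidence bears on these results.

From the compounds shown here alone, it remains open whether morpholin-4-yl, 4-hydroxypiperidin-1-yl or a longer chain would move the number beyond the scatter.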